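The compounds below may be only part of what the source reports. "The series", "measured", "known", "first", "only" and "open" are said of these compounds alone.

Of the compounds shown here, three built on one shared core have been measured in a functional assay on U-251 cells (Homo sapiens) for inhibition, read by sulforhodamine B assay, with a stated time of 48 h, tested at 10 uM; a lower number here means less inhibition, a higher number more inhibition at the concentration tested (going by the name of the read-out). Compound 1, `O=Cc1ccc(-c2cn3ccnc3c(-c3ccc4ncn(C5CCCCC5)c4c3)n2)cc1`, carries a 4-formylphenyl group and in this assay gives 32%, the highest of the three numbers. Compound 2, `CC(=O)c1ccc(-c2cn3ccnc3c(-c3ccc4ncn(C5CCCCC5)c4c3)n2)cc1`, differs from it by a methyl in place of hydrogen on a carbonyl carbon and gives 3.02%; the step of a number 29 percentage points lower from compound 1 to compound 2 (beyond the scatter) lies beyond the scatter. Compound 3, `COc1ccccc1-c1cn2ccnc2c(-c2ccc3ncn(C4CCCCC4)c3c2)n1`, carries a 2-methoxyphenyl in place of the 4-formylphenyl on the same aromatic carbon and gives 21%; the step of a number 11 percentage points lower from compound 1 to compound 3 (beyond the scatter) is also beyond the scatter. Compound 4, `c1csc(-c2cn3ccnc3c(-c3ccc4ncn(C5CCCCC5)c4c3)n2)c1`, has not yet been measured. thiophen-2-yl in place of 4-formylphenyl on an aromatic carbon Both measured steps away from compound 1 altered the group on this aromatic carbon, and both lowered the inhibition by a modest amount; nothing measured here shows a change at this place raising it. For compound 4 a drop beyond the scatter is therefore expected, of a size near the smaller of the two measured steps, estimated as a number 14 percentage points lower from compound 1 to compound 4 (beyond the scatter). Compound 4 is expected to give about 18%, with a likely range from 4% to 34%.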

Compound 4, a percentage reported as inhibition, at one concentration (the size of the read-out at that concentration, not a potency): 3.92%
The estimate for compound 4 lay 14.1 percentage points above the measured number; the measured number lies below the stated range.
By their numbers in this assay, from the lowest: compounds 2 and 4 (each within the scatter of the next); then compound 3; then compound 1.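

In this assay, putting a thiophen-2-yl on this aromatic carbon in place of the 4-formylphenyl gives a number 28.1 percentage points lower from compound 1 to compound 4 (beyond the scatter) and, set against the 2-methoxyphenyl, gives a number 17.1 percentage points lower from compound 3 to compound 4 (beyond the scatter), so the choice of group here matters even among replacements that have no carbonyl. Against the 4-acetylphenyl the same swap gives a number 0.9 percentage points higher from compound 2 to compound 4 (within the scatter), which means that a five-membered aromatic ring with one hetero atom and a six-membered ring carrying an acetyl group cannot be told apart in this read-out, although they share little beyond being aromatic. Compound 1 remains the highest of the four, so none of the changes to its 4-formylphenyl group raises the inhibition, and no available information explains why these groups differ.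

The compounds shown leave open whether the formyl group itself matters, which a plain phenyl or a 4-(hydroxymethyl)phenyl group at this carbon could help to test. They also leave open whether a phenyl ring carrying an amine or a carboxylic acid at the same spot as the formyl group would match or exceed compound 1.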